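The source may hold more compounds than are shown below. What is called first, only, known or untested is meant among the compounds shown, and "the series" means these compounds.

Measured in a functional assay on isolated protein for agonist activity at Glucose-dependent insulinotropic receptor (Rattus norvegicus), read by HTRF and cAMP accumulation; a higher number here means that more compound is needed for the effect, a lower number that less compound is needed:
compound 1, `CC(C)OC(=O)N1CCC(O[C@H]2CC[C@H](Oc3cnc(S(C)(=O)=O)cn3)CC2)CC1`: 119 nM
compound 2, `CS(=O)(=O)c1cnc(O[C@H]2CC[C@H](OC3CCN(C(=O)Oc4ccccc4)CC3)CC2)cn1`: 71.8 nM
compound 3, `CC(C)c1noc(CN2CCC(O[C@H]3CC[C@H](Oc4cnc(S(C)(=O)=O)cn4)CC3)CC2)n1`: 97.9 nM

Compound 3 stands second highest of the three numbers, but a 1.2-fold lower number from compound 1 to compound 3 (0.08 log units; within the scatter) and a 1.4-fold higher number from compound 2 to compound 3 (0.13 log units; within the scatter) are both within the scatter, so the three compounds are not separated from one another. Compound 4, `CC(F)Cc1nc(CN2CCC(O[C@H]3CC[C@H](Oc4cnc(S(C)(=O)=O)cn4)CC3)CC2)no1`, differs from compound 3 by 5-(2-fluoropropyl)-1,2,4-oxadiazol-3-yl in place of 3-isopropyl-1,2,4-oxadiazol-5-yl on a saturated chain carbon bound to an amine nitrogen in a ring. Within the data shown here, no measured step touches this group: the two steps that reach compound 3 exchange the substituent on the ring amine nitrogen for the oxadiazolylmethyl group and stay within the scatter, and they say nothing about the new alkyl or the shifted ring attachment. With no guidance beyond this, no step beyond the scatter is expected, a 1.0-fold higher number from compound 3 to compound 4 (0.01 log units; within the scatter). Compound 4 is therefore estimated at 100 nM in this assay, with a range of 40 nM to 250 nM.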

Compound 4, half-maximal effective concentration: 267 nM
Estimate against measurement, compound 4: 2.7-fold (0.43 log units) below, and the stated range ends below it.
By their numbers in this assay, from the lowest: compounds 2, 3 and 1 (each within the scatter of the next); then compound 4.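

In this assay, among these compounds, the earlier compounds stayed within the scatter whatever stood on the amine nitrogen in a ring, but compound 4 separates from them: a 2.7-fold higher number from compound 3 to compound 4 (0.44 log units; beyond the scatter) and a 3.7-fold higher number from compound 2 to compound 4 (0.57 log units; beyond the scatter) and a 2.2-fold higher number from compound 1 to compound 4 (0.35 log units; beyond the scatter) all lie beyond the scatter. The oxadiazole exchange on this saturated chain carbon is therefore not neutral, though it alters the alkyl group and the ring attachment together. Nothing available explains this step. Going by these compounds, whether the fluorine or the ring attachment carries the step stays open, and a 5-isopropyl-1,2,4-oxadiazol-3-yl group would separate the two.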